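A few compounds are considered here, and "the series" means these few. Any claim that something is new, unique, unknown or untested is made for them only; others in the source may bear on it.

Compound 2 `CN1CC(=O)Nc2cnc(Nc3ccccc3)nc21` gives only a limit in a functional assay on T47D cells (Homo sapiens) for cytotoxicity, read by MTT assay, with a stated time of 48 h (on this read-out lower numbers stand for stronger inhibition and higher numbers for weaker inhibition), namely > 100000 nM. Compound 1 `COc1cccc(Nc2ncc3c(n2)NCC(=O)N3)c1` also sits at a limit in this assay, > 100000 nM, so that the limit of > 100000 nM in this assay, at which 2 of the 3 values shown sit, covers two of the three values. Among the measured compounds shown here, compound 3 `CN1CC(=O)Nc2cnc(Nc3ccc(Cl)cc3)nc21` gives the one numbered value, 36000 nM, and the step of an at least 2.7-fold lower number from compound 2 to compound 3 (0.44 log units; beyond the scatter) is the only measured change at an aromatic carbon of this ring. Compound 4 `COc1cccc(Nc2ncc3c(n2)N(C)CC(=O)N3)c1` carries methoxy in place of hydrogen on an aromatic carbon. The methoxy group is already present in compound 1, which gives > 100000 nM as a limit. For the measured compounds named here, the chloro change was the sole step beyond the scatter, and the methoxy change is not expected to match it. The step from compound 2 to compound 4 is therefore expected as a number no higher from compound 2 to compound 4 (the limit leaves the size open). Compound 4 is estimated at 100000 nM, within 40000 nM to 300000 nM.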

Compound 4, half-maximal inhibitory concentration: > 100000 nM
Compound 4 gave a limit, no number; the forecaster's own chance of this, stated with the estimate: 60%; the middle value lies on the limit itself.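

In this assay, among the compounds shown here, compound 4 gives > 100000 nM, a limit, so no new step to compound 4 can be read from compound 1 or compound 2: the limit of > 100000 nM in this assay, at which 3 of the 4 values shown sit. The compounds shown leave open whether methoxy in place of hydrogen, or methyl in place of hydrogen on the nitrogen, changes the read-out at all.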